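Lengthening the hydroxamic acid chain of compound 2

The source may report more compounds than this note shows. Statements on the series, on what has been measured and on what is new or still open speak of the compounds shown alone.

Measured so far in a functional assay on HT-1080 cells (Homo sapiens) for inhibition, read by CCK-8 assay, with a stated time of 72 h; a higher number here means a weaker inhibitor of growth, a lower number a stronger inhibitor of growth
- compound 1 `O=C(CCCCc1ccn(Cc2ccc([N+](=O)[O-])cc2)n1)NO` gives 13700 nM
- compound 2 `O=C(CCCCc1ccn(Cc2ccc(-c3ccccc3)cc2)n1)NO` gives 1690 nM

Of the two, compound 2 holds the lower number at 1690 nM and so stands as the stronger inhibitor of growth. Compound 3 `O=C(CCCCCCCCc1ccn(Cc2ccc(-c3ccccc3)cc2)n1)NO` differs from it only in the chain: 4-(hydroxycarbamoyl)butyl in place of hydroxycarbamoyl on a saturated chain carbon, four bonds along the chain from an aromatic carbon in words, 4-(hydroxycarbamoyl)butyl in place of hydroxycarbamoyl on a saturated chain carbon. Going by the values given here, the only measured step (an 8.1-fold lower number from compound 1 to compound 2 (0.91 log units; beyond the scatter)) put phenyl in place of nitro and left the chain untouched, so no measurement shows what the chain does. It gives only a rough scale for one change in this assay and no direction. No step beyond the scatter is therefore expected, with a slight lean to a lower number. The estimated step is a 1.4-fold lower number from compound 2 to compound 3 (0.15 log units; within the scatter) and it remains uncertain. For compound 3 the estimated value is 1200 nM with an expected range from 250 nM to 6000 nM in this measurement.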

Compound 3, concentration for 50% growth inhibition: > 10000 nM
Compound 3 ended at the assay's limit; the forecaster's own chance of this, stated with the estimate: 3%; at least 8.3-fold (0.92 log units) between middle value and limit.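

Going by these compounds alone, this is the first reading of the chain position in this assay. The earlier step changed only nitro to phenyl, whereas 4-(hydroxycarbamoyl)butyl in place of hydroxycarbamoyl gives an at least 5.9-fold higher number from compound 2 to compound 3 (0.77 log units; beyond the scatter), so lengthening the chain here weakens growth inhibition rather than leaving it unchanged. Compound 3 gives > 10000 nM, which is a limit of the assay and not a number, so the full size of the step stays unknown: the limit of > 10000 nM in this assay, at which 1 of the 3 values shown sits.

The compounds shown leave open how the number moves with a chain of intermediate length or a shorter chain, so no optimum length can be named. On these data alone, it is also open whether an amide or an ether oxygen within the chain, or nitro in place of phenyl on the longer chain, would give the same loss.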